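Shortening the chain on the core of compound 2

The source may report more compounds than this note shows. Statements on the series, on what has been measured and on what is new or still open speak of the compounds shown alone.

Compound 2 `CCCCn1cnc2c(NCc3ccc(C(=O)Nc4ccccc4N)cc3)nc(Cl)nc21` gives 23.7% in a functional assay on NCI-H460 cells (Homo sapiens) for antiproliferative activity, read by CCK-8 assay, with a stated time of 72 h, tested at 8 uM (a higher number here means a stronger effect of the compound at the concentration tested, a lower number a weaker effect), and stands lowest of the two measured compounds; compound 1 `Cc1ccc(Nc2nc(Cl)nc3c2ncn3Cc2ccc(C(=O)Nc3ccccc3N)cc2)cc1` gives 82.5% in this assay, a gap beyond the scatter. Compound 3 `CCCn1cnc2c(NCc3ccc(C(=O)Nc4ccccc4N)cc3)nc(Cl)nc21` has not yet been measured and differs from compound 2 by hydrogen in place of methyl on a saturated chain carbon, three bonds along the chain from an aromatic nitrogen. Going by the values given here, no step of this kind has been measured. A change as small as this is expected to move the read-out by no more than the scatter, so compound 3 is expected to show a number 1.7 percentage points lower from compound 2 to compound 3 (within the scatter) and to land near 22%, within 5% to 45%.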

Compound 3, a percentage reported as inhibition, at one concentration (the size of the read-out at that concentration, not a potency): 39.2%
For compound 3 the middle estimate is 17.2 percentage points below the measured one, within the range that was stated.
By their numbers in this assay, from the lowest: compound 2; then compound 3; then compound 1.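

The chain on the core is not silent in this assay: butyl to propyl gives a number 15.5 percentage points higher from compound 2 to compound 3 (beyond the scatter) and so registers as a modest change. Going by these compounds alone, this is the first step read at this position, on a saturated chain carbon, three bonds along the chain from an aromatic nitrogen, and it favours the shorter chain of the pair. Nothing measured here accounts for the change.

On these data alone, whether an ethyl chain continues this direction stays open. So does the effect of an amine or a carboxylic acid at the end of the chain.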